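Working notes: 3-methoxyphenyl to 2-methoxyphenyl

A few compounds are considered here, and "the series" means these few. Any claim that something is new, unique, unknown or untested is made for them only; others in the source may bear on it.

Measured so far in a functional assay on 1A9 cells (Homo sapiens) for cytotoxicity; on this read-out lower numbers stand for an effect already at smaller amounts and higher numbers for an effect only at larger amounts of compound:
- compound 1 `COC1=C(C)C(=O)/C(=C(O)/C=C/c2ccc(Br)cc2)C(=O)C1(C)C` gives 1.1 ug/mL
- compound 2 `COC1=C(C)C(=O)/C(=C(O)/C=C/c2cccc(OC)c2)C(=O)C1(C)C` gives 2.9 ug/mL

Among the measured compounds shown here, of the two numbers available, compound 2 holds the higher, and compound 1 is its only neighbour. Next to be read is compound 3 `COC1=C(C)C(=O)/C(=C(O)/C=C/c2ccccc2OC)C(=O)C1(C)C`, which has the same atoms as compound 2, joined differently: 2-methoxyphenyl in place of 3-methoxyphenyl on a double-bonded chain carbon bound to a double-bonded chain carbon. The group stays on a double-bonded chain carbon bound to a double-bonded chain carbon, and the rest of the molecule is shared.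

For the measured compounds named here, only one measured step bears on this change: a 2.6-fold higher number from compound 1 to compound 2 (0.42 log units; beyond the scatter). That step was modest, and it exchanged 4-bromophenyl for 3-methoxyphenyl, so it does not isolate a shift of the methoxy group. Going by the values given here, no measured pair shows such a shift alone. With so little to go on, no step beyond the scatter is expected in this assay, in either direction. The estimated change is a 1.1-fold lower number from compound 2 to compound 3 (0.05 log units; within the scatter) on this reasoning. The estimate for compound 3 is 2.6 ug/mL as the expected value, with an expected range from 1.1 ug/mL to 6 ug/mL for now.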

Compound 3, concentration for half-maximal effect: 2.5 ug/mL
For compound 3 the middle estimate is 1.0-fold (0.02 log units) above the measured one; measured number inside the range.
By their numbers in this assay, from the lowest: compound 1; then compounds 3 and 2 (each within the scatter of the next).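

In this assay the shift of the methoxy group gives a 1.2-fold lower number from compound 2 to compound 3 (0.06 log units; within the scatter) on this read-out, so 2-methoxyphenyl and 3-methoxyphenyl on a double-bonded chain carbon bound to a double-bonded chain carbon are not told apart, a comparison that the earlier pair could not offer. 4-Bromophenyl now stands apart from both methoxyphenyl groups, as a 2.3-fold higher number from compound 1 to compound 3 (0.36 log units; beyond the scatter) is of similar kind to a 2.6-fold higher number from compound 1 to compound 2 (0.42 log units; beyond the scatter) and both steps lie beyond the scatter. Nothing available explains the gap between 4-bromophenyl and the methoxyphenyl groups, or the lack of a separation between the two methoxyphenyl groups.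

The compounds shown leave open whether the gap follows the bromine or its place on the ring, a question that 4-methoxyphenyl, 3-bromophenyl or 2-bromophenyl at this position would address. Also open, as far as these compounds go, is how a phenyl group carrying an amine or a carboxylic acid would read at this position in this assay on the shared core.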